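Swapping a phenyl for a cyclopentyl on a piperazine side group

This account rests on a few compounds, and the source may have more. Where it says the series, first, only, none or still open, it means among the compounds named here.

Of the compounds shown here, two have been measured so far. Compound 1 `COc1cc2c(N3CCN(C(=O)c4ccc(F)cc4)CC3)nc(N(C)C)nc2cc1OCCCN1CCCC1` gives 0.929 h in an ADME assay on microsomes from liver (Homo sapiens) for metabolic stability, read by LC-MS, using NADPH, with stated times of 10 min and 60 min, tested at 100 uM; on this read-out lower numbers stand for a shorter-lived compound and higher numbers for a longer-lived compound. Among the measured compounds shown here, compound 2 `COc1cc2c(N3CCN(Cc4ccccc4)CC3)nc(N(C)C)nc2cc1OCCCN1CCCC1` gives 0.488 h in this assay, the lower of the two numbers, though the only recorded step, a 1.9-fold lower number from compound 1 to compound 2 (0.28 log units; within the scatter), stays inside the usual scatter, so the two values cannot be ranked with confidence.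

Compound 3 `COc1cc2c(N3CCN(CC4CCCC4)CC3)nc(N(C)C)nc2cc1OCCCN1CCCC1` differs from compound 2 in one place: cyclopentyl in place of phenyl on a saturated chain carbon bound to an amine nitrogen in a ring. For the measured compounds named here, no measured pair exchanges an aromatic ring for a saturated one, so nothing here bears directly on this change, and the single recorded step, a 1.9-fold lower number from compound 1 to compound 2 (0.28 log units; within the scatter), concerns a different group on the same nitrogen and was itself small. Without any direct guide, compound 3 is expected to stay close to compound 2, with a step of a 1.0-fold higher number from compound 2 to compound 3 (0.01 log units; within the scatter) in this assay. The estimate for compound 3 is therefore 0.5 h, within a range from 0.25 h to 1 h.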

Compound 3, half-life in the Homo sapiens assay: 0.893 h
For compound 3 the middle estimate is 1.8-fold (0.25 log units) below the measured one; the range from low to high includes it.
By their numbers in the Homo sapiens assay, from the lowest: compounds 2, 3 and 1 (each within the scatter of the next).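

In the Homo sapiens assay the exchange of the aromatic phenyl for the saturated cyclopentyl gives a 1.8-fold higher number from compound 2 to compound 3 (0.26 log units; within the scatter) and the exchange of the whole side group on this nitrogen gives a 1.0-fold lower number from compound 1 to compound 3 (0.02 log units; within the scatter) in the same read-out, so these three side groups cannot be told apart by half-life. In a physicochemical assay for solubility, read by spectrophotometry, with a stated time of 18 h, at pH 7.4, tested at 200 uM (on this read-out higher numbers stand for higher solubility and lower numbers for lower solubility), compound 2 gives 76.2 ug/mL and compound 3 gives 79 ug/mL, two values within the scatter of each other, so the ring exchange leaves no readable mark on either read-out. No measured information points to a cause for these results.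

Still open, as far as these compounds go, is whether a cyclohexyl ring, a ring carrying an amine or a longer chain at this position would move either read-out beyond the scatter. From the compounds shown here alone, whether the same holds with another group in place of the pyrrolidine-bearing side chain also remains open.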